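Halogen on the benzyl group: from compound 3 to compound 4

A few compounds are considered here, and "the series" means these few. Any claim that something is new, unique, unknown or untested is made for them only; others in the source may bear on it.

The series keeps one core, seen in compound 1 `COc1cc(N)c(Cl)cc1NC(=O)C1CCN(CC2CC2)CC1`, and varies the group on a saturated chain carbon bound to an amine nitrogen in a ring. In a functional assay on the whole organism for antagonist activity, with Mus musculus as the target (on this read-out lower numbers stand for an effect already at smaller amounts and higher numbers for an effect only at larger amounts of compound), compound 1 gives only a limit, > 10 mg/kg. Compound 2 `COc1cc(N)c(Cl)cc1NC(=O)C1CCN(Cc2ccccc2)CC1` gives 0.5 mg/kg in this assay. Compound 3 `COc1cc(N)c(Cl)cc1NC(=O)C1CCN(Cc2ccccc2F)CC1` gives only a limit in this assay, > 4 mg/kg, so it stands at a limit and not at a number. The measured steps are an at least 20-fold lower number from compound 1 to compound 2 (1.30 log units; beyond the scatter) and an at least 8.0-fold higher number from compound 2 to compound 3 (0.90 log units; beyond the scatter).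

Compound 4 `COc1cc(N)c(Cl)cc1NC(=O)C1CCN(Cc2cccc(Cl)c2)CC1` differs from compound 3 by 3-chlorophenyl in place of 2-fluorophenyl on a saturated chain carbon bound to an amine nitrogen in a ring. The step that bears most directly on it is an at least 8.0-fold higher number from compound 2 to compound 3 (0.90 log units; beyond the scatter), where fluoro entering cost activity; the step of an at least 20-fold lower number from compound 1 to compound 2 (1.30 log units; beyond the scatter) shows the phenyl group itself is favourable. Among the compounds with values here, no measured pair shows chloro entering a phenyl ring, so the direction is uncertain, and since compound 3 is a limit the step from it cannot be sized. The estimate for compound 4 is 2 mg/kg, with a range of 0.5 mg/kg to 10 mg/kg. The expected step is therefore an at least 2.0-fold lower number from compound 3 to compound 4 (0.30 log units; that floor lies within the scatter), with little confidence.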

Compound 4, dose for half-maximal effect: > 4 mg/kg
Compound 4 was reported as a limit; the forecaster's own chance of this, stated with the estimate: 40%; middle value at least 2.0-fold (0.30 log units) from the limit.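

In this assay, the 3-chlorophenyl group also fails to hold the level of the plain phenyl group, with an at least 8.0-fold higher number from compound 2 to compound 4 (0.90 log units; beyond the scatter). The loss seen with 2-fluorophenyl is therefore not unique to that group: both halogen-bearing benzyl groups shown lose against compound 2, and no compound shown goes against this. The steps from compound 1 and from compound 3 to compound 4 cannot be read, and compound 3 and compound 4 share one limit: the limit of > 4 mg/kg in this assay, at which 2 of the 4 values shown sit.

Going by these compounds, how far each of these two compounds lies past that limit remains open, and so does whether the halogen or its ring place matters more, which 2-chlorophenyl or 3-fluorophenyl would help separate. Also open, on these data alone, is whether a methyl or an amine on the phenyl ring, or a longer chain to the phenyl ring, would keep the level of compound 2.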